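A few compounds are considered here, and "the series" means these few. Any claim that something is new, unique, unknown or untested is made for them only; others in the source may bear on it.

In a functional assay on MCF7 cells (Homo sapiens) for antiproliferative activity, read by MTT assay (on this read-out higher numbers stand for weaker inhibition and lower numbers for stronger inhibition), compound 1 `O=C1Nc2ccc(Br)cc2/C1=N/NC(=O)c1cc2cc(Br)ccc2o1` gives 3410 nM and compound 2 `Cc1ccc2c(c1)/C(=N/NC(=O)c1cc3cc(Br)ccc3o1)C(=O)N2` gives 3450 nM, which places compound 2 level with compound 1 within the scatter. Compound 3 `COc1ccc2c(c1)/C(=N/NC(=O)c1cc3cc(Br)ccc3o1)C(=O)N2` has methoxy in place of methyl on an aromatic carbon. Within the data shown here, the only measured step, a 1.0-fold higher number from compound 1 to compound 2 (0.01 log units; within the scatter), replaces bromo with methyl and stays within the scatter. It is a single step and involves no methoxy, so it is weak guidance, and no change beyond the scatter is expected in this assay. The expected step is a 1.0-fold lower number from compound 2 to compound 3 (0.02 log units; within the scatter). Compound 3 is estimated at 3300 nM, with an expected range of 1500 nM to 7000 nM.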

Compound 3, half-maximal inhibitory concentration: 2270 nM
The estimate for compound 3 lay 1.5-fold (0.16 log units) above the measured number; the range from low to high includes it.
By their numbers in this assay, from the lowest: compounds 3, 1 and 2 (each within the scatter of the next).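

In this assay methoxy on this aromatic carbon, which brings an oxygen and a hydrogen-bond acceptor in place of methyl, stays level with methyl (a 1.5-fold lower number from compound 2 to compound 3 (0.18 log units; within the scatter)) and with bromo (a 1.5-fold lower number from compound 1 to compound 3 (0.18 log units; within the scatter)). Adding the acceptor therefore moves the number no further than the scatter, and bromo, methyl and methoxy cannot be told apart at this place. Nothing available gives a reason for this flat response.

From the compounds shown here alone, whether any group here can move the number beyond the scatter stays open, for example an amine, a carboxylic acid or a longer chain. Going by these compounds, the rest of the shared core is constant across these compounds, so the effect of changes elsewhere also remains unknown.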